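The compounds below may be only part of what the source reports. "The series", "measured", "known", "first", "only" and "open" are said of these compounds alone.

Within the data shown here, compound 2, `Cn1cc(C(=O)c2ccc(F)cc2)cc1/C=C/C(=O)NO`, is one of two compounds measured in an assay on isolated protein with histone deacetylase HD2 (Zea mays) as the target; a lower number here means a stronger inhibitor, a higher number a weaker inhibitor. In this assay compound 2 gives 2290 nM, the highest number of the two. Among the measured compounds shown here, the only other measured compound, compound 1, `Cn1cc(C(=O)c2ccccc2)cc1CCC(=O)NO`, gives 4.37 nM in this assay, a far lower number; compound 1 and compound 2 differ in more than one place, so their gap cannot be tied to a single change.

Compound 3, `Cn1cc(C(=O)c2ccccc2)cc1/C=C/C(=O)NO`, has not yet been measured in this assay. It differs from compound 2 in a single way: hydrogen in place of fluoro on an aromatic carbon. The change sits on an aromatic carbon of a six-membered aromatic ring of carbon only, para to a large group, and the chain that links the shared core to the hydroxamic acid is unchanged.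

For the measured compounds named here, no pair of measured compounds differs in only this place, so there is no step to lean on. The change is small, and a step in this assay of no more than the usual scatter is expected, in either direction. The estimated step from compound 2 to compound 3 is a 1.5-fold lower number from compound 2 to compound 3 (0.18 log units; within the scatter). For compound 3 in this assay the expected value is 1500 nM, with a range from 300 nM to 7000 nM.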

Compound 3, inhibition constant: 2290 nM
Compound 3: middle estimate off by 1.5-fold (0.18 log units), on the low side; low and high end bracket the measured number.
By their numbers in this assay, from the lowest: compound 1; then compounds 2 and 3 (each within the scatter of the next).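

Swapping the fluoro for hydrogen on the aromatic ring leaves the reading in this assay flat, with no change at the digits printed from compound 2 to compound 3 (within the scatter) as the step, so with the 2-(hydroxycarbamoyl)ethenyl chain in place, 4-fluorophenyl and phenyl cannot be told apart. Among these compounds, compound 3 also gives the first pair that differs in one place only in the chain: putting 2-(hydroxycarbamoyl)ethenyl in place of 2-(hydroxycarbamoyl)ethyl gives a 520-fold higher number from compound 1 to compound 3 (2.72 log units; beyond the scatter) as the step, which is very large next to the step at the ring. The wide gap that could not earlier be tied to a single change can now be tied to the chain, at least for the phenyl compounds, although no measurement here explains why the chain counts for so much and the fluoro for so little.

As far as these compounds go, it remains open whether the fluoro would be just as silent on a compound carrying the 2-(hydroxycarbamoyl)ethyl chain, and whether a methoxy group, an amine or a carboxylic acid at the same place on the ring would also leave the number where it is. Also open, from the compounds shown here alone, is how a longer chain leading to the hydroxamic acid would compare with the 2-(hydroxycarbamoyl)ethyl chain.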